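This account rests on a few compounds, and the source may have more. Where it says the series, first, only, none or still open, it means among the compounds named here.

Values so far in an ADME assay on MT4 cells (Homo sapiens) for cytotoxicity, read by MTT assay, with a stated time of 5 days; a higher number here means that more compound is tolerated, a lower number that less compound is tolerated:
- Compound 1 `COc1cc2nc([S+]([O-])CC(=O)Nc3cccc([N+](=O)[O-])c3)nc(Nc3c(Cl)cc(/C=C/C#N)cc3Cl)c2cc1OC` gives >= 83200 nM as a limit of the assay
- Compound 2 `COc1cc2nc([S+]([O-])CC(=O)Nc3cccc(Cl)c3)nc(Nc3c(Cl)cc(/C=C/C#N)cc3Cl)c2cc1OC` gives 68900 nM
- Compound 3 `COc1cc2nc([S+]([O-])CC(=O)Nc3cccc(C(F)(F)F)c3)nc(Nc3c(Cl)cc(/C=C/C#N)cc3Cl)c2cc1OC` gives 21800 nM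

Of these three, compound 3 stands lowest, so it is the one tolerated least. Compound 4 `COc1cc2nc([S+]([O-])CC(=O)Nc3cccc(C#N)c3)nc(Nc3c(Cl)cc(/C=C/C#N)cc3Cl)c2cc1OC` is compound 3 with cyano in place of trifluoromethyl on an aromatic carbon, meta to a large group cyano in place of trifluoromethyl on an aromatic carbon and it is still unmeasured.

Two measured steps bring trifluoromethyl in. Replacing chloro gave a 3.2-fold lower number from compound 2 to compound 3 (0.50 log units; beyond the scatter) and replacing nitro gave an at least 3.8-fold lower number from compound 1 to compound 3 (0.58 log units; beyond the scatter) while chloro in place of nitro gave an at least 1.2-fold lower number from compound 1 to compound 2 (0.08 log units; that floor lies within the scatter). Going by the values given here, no cyano compound has a value yet, but losing trifluoromethyl is expected to raise the number modestly. The expected step is a 2.5-fold higher number from compound 3 to compound 4 (0.40 log units; beyond the scatter). The estimate for compound 4 is 55000 nM, with an expected range of 25000 nM to 95000 nM.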

Compound 4, half-maximal cytotoxic concentration: >= 70300 nM
Compound 4: a limit, no number; the forecaster's own chance of this, stated with the estimate: 25%; at least 1.2-fold (0.10 log units) between middle value and limit.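

In this assay compound 4 reads as a limit, not a number: the limit of >= 70300 nM in this assay, at which 1 of the 4 values shown sits. Cyano in place of trifluoromethyl gives an at least 3.2-fold higher number from compound 3 to compound 4 (0.50 log units; beyond the scatter) and leaves compound 3 as the only one of the four standing apart at the low end. Cyano in place of chloro gives an at least 1.0-fold higher number from compound 2 to compound 4 (0.00 log units; that floor lies within the scatter) and sets no order between those two, and the step between compound 1 and compound 4 cannot be read. As far as these compounds go, how far compound 4 lies past its limit stays open. So does how an amine or a carboxylic acid on this aromatic carbon would read.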